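The source may hold more compounds than are shown below. What is called first, only, known or untested is meant among the compounds shown, and "the series" means these compounds.

Values so far in a functional assay on HeLa cells (Homo sapiens) for antiproliferative activity, read by cell counting, with a stated time of 2 days; a higher number here means a weaker inhibitor, a lower number a stronger inhibitor

Compound 1 `COc1cc(C(=O)c2sc(Nc3ccccc3)nc2N)cc(OC)c1OC` with 14 nM
Compound 2 `COc1ccc(Nc2nc(N)c(C(=O)c3ccccc3)s2)cc1` with 230 nM
Compound 3 `COc1ccc(Nc2nc(N)c(C(=O)c3ccc(Cl)cc3)s2)cc1` with 83 nM

In this assay compound 3 (83 nM) holds the middle place of the three numbers. Its number is lower than that of compound 2 (230 nM) and higher than that of compound 1 (14 nM). Compound 4 `COc1ccc(Nc2nc(N)c(C(=O)c3ccc(Br)cc3)s2)cc1` has not yet been measured. Its difference from compound 3 is bromo in place of chloro on an aromatic carbon (in short, bromo in place of chloro on an aromatic carbon, which turns 4-chlorophenyl into 4-bromophenyl).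

Among the compounds with values here, only one measured step bears on this change. It is a 2.8-fold lower number from compound 2 to compound 3 (0.44 log units; beyond the scatter) (modest), and it comes with the gain of a chloro group where compound 2 has only a hydrogen. Within the data shown here, no measured compound carries bromo, so the data offer no direct comparison of bromo with chloro. Here one substituent replaces another rather than hydrogen, so the step expected in this assay is smaller than that modest one. It is expected to stay within the scatter, with at most a slight lean towards a lower number.

The estimated step is a 1.2-fold lower number from compound 3 to compound 4 (0.07 log units; within the scatter) and would not be distinguishable from no change. The estimate for compound 4 is 70 nM (expected range 35 nM to 150 nM).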

Compound 4, half-maximal inhibitory concentration: 79 nM
Compound 4: the middle estimate sits 1.1-fold (0.05 log units) below what was measured; measured number inside the range.
By their numbers in this assay, from the lowest: compound 1; then compounds 4 and 3 (each within the scatter of the next); then compound 2.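

In this assay the change from 4-chlorophenyl to 4-bromophenyl gives a 1.1-fold lower number from compound 3 to compound 4 (0.02 log units; within the scatter) and so leaves the two substituents indistinguishable on this aromatic carbon, para to a large group. Measured against hydrogen, bromo gives a 2.9-fold lower number from compound 2 to compound 4 (0.46 log units; beyond the scatter) and thereby shows that the earlier gain, seen with chloro as a 2.8-fold lower number from compound 2 to compound 3 (0.44 log units; beyond the scatter), is not confined to that one substituent, since both compound 3 and compound 4 stand apart from compound 2 by a modest step of much the same size. No measurement at hand offers a reason for this likeness between chloro and bromo.

Whether the lower number at this place holds for a group of a different kind, such as a carboxylic acid, a nitrile or an amine, stays open, as the only replacements for hydrogen shown here are these two single atoms. Compound 1 differs from compound 2, compound 3 and compound 4 in more than one place, so the compounds shown cannot say which of those differences accounts for the distance between its number and theirs.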